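The compounds below may be only part of what the source reports. "The series", "measured", "known", "first", "only" and "open" are said of these compounds alone.

Measured in a functional assay on MGC-803 cells (Homo sapiens) for inhibition, read by CCK-8 assay, with a stated time of 48 h; on this read-out lower numbers stand for stronger inhibition and higher numbers for weaker inhibition:
- compound 1 `CCN1CCN(C(=S)SCC(=O)N(Cc2ccc(OC)cc2)c2cc(OC)c(OC)c(OC)c2)CC1`: 9890 nM
- compound 2 `COc1ccc(CN(C(=O)CSC(=S)N2CCCc3cc(C)ccc32)c2cc(OC)c(OC)c(OC)c2)cc1`: 6490 nM

These two values lie within the scatter of each other, so compound 1 cannot be ranked against compound 2. Compound 3 `COc1ccc(CN(C(=O)CN2CCN(C(C)=O)CC2)c2cc(OC)c(OC)c(OC)c2)cc1` keeps the rest of compound 1 but changes one group: a group of 9 heavy atoms (6 carbon, 2 nitrogen, 1 oxygen; one six-membered non-aromatic ring with 2 hetero atoms) in place of a group of 11 heavy atoms (7 carbon, 2 nitrogen, 2 sulfur; one six-membered non-aromatic ring with 2 hetero atoms), on a saturated chain carbon bound to a carbonyl carbon. For the measured compounds named here, only one measured step bears on this change. That step, a 1.5-fold lower number from compound 1 to compound 2 (0.18 log units; within the scatter), replaced the group on the thiocarbonyl carbon and kept the thiocarbonyl itself. Going by the values given here, no measured compound shows what happens when the thiocarbonyl is lost, so this evidence is indirect and the range must stay wide. No step beyond the scatter is therefore expected in this assay. The expected change is a 1.2-fold higher number from compound 1 to compound 3 (0.08 log units; within the scatter). For compound 3 the estimated value is 12000 nM, with an expected range of 4000 nM to 35000 nM.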

Compound 3, half-maximal inhibitory concentration: 12800 nM
Estimate against measurement, compound 3: 1.1-fold (0.03 log units) below; the measured number falls inside the stated range.
By their numbers in this assay, from the lowest: compounds 2, 1 and 3 (each within the scatter of the next).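

Replacing the whole group on a saturated chain carbon bound to a carbonyl carbon with 4-acetylpiperazin-1-yl gives, in this assay, a 1.3-fold higher number from compound 1 to compound 3 (0.11 log units; within the scatter). Compound 2 had kept the thiocarbonyl, so the earlier comparison could not address its loss; here the thiocarbonyl and both sulfur atoms leave without a step beyond the scatter. For this pair, then, the thiocarbonyl is not needed to hold the number at this level, and no measurement shown here offers an explanation for that.

Going by these compounds, neither measured step has yet moved the number beyond the scatter, so it remains open whether any group at this place can do so. A morpholin-4-yl group, a primary amine or a carboxylic acid on the same chain carbon would test this, and the shared core may matter more than this position.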